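Swapping the thiophene of compound 3 for an aminopyrimidine

The compounds below may be only part of what the source reports. "The series", "measured", "known", "first", "only" and "open" are said of these compounds alone.

Among the three measured compounds, compound 3 `COc1ccc(-c2cc3ccccc3nc2/C=C/C(=O)c2cccs2)cc1` gives the lowest number in a functional assay on NCI-H1299 cells (Homo sapiens) for antiproliferative activity, read by XTT assay, with a stated time of 72 h (a higher number here means a weaker inhibitor, a lower number a stronger inhibitor), at 720 nM; compound 1 `COc1ccc(-c2cc3ccccc3nc2/C=C/C(=O)c2c(OC)cccc2OC)cc1` gives 4710 nM, and compound 2 `COc1ccc(-c2cc3ccccc3nc2/C=C/C(=O)c2ccc(N)cc2)cc1` gives 6510 nM. Compound 4 `COc1ccc(-c2cc3ccccc3nc2/C=C/C(=O)c2cnc(N)nc2C)cc1` is compound 3 with 2-amino-4-methylpyrimidin-5-yl in place of thiophen-2-yl on a carbonyl carbon. Among the measured compounds shown here, two measured steps bear on this: the number fell a 6.5-fold lower number from compound 1 to compound 3 (0.82 log units; beyond the scatter) and a 9.0-fold lower number from compound 2 to compound 3 (0.96 log units; beyond the scatter), so moving away from thiophen-2-yl to a six-membered aromatic ring with an amino group, as in compound 2, went with a weaker inhibitor. A modest rise is therefore expected for compound 4, a 4.9-fold higher number from compound 3 to compound 4 (0.69 log units; beyond the scatter). Compound 4 is estimated at 3500 nM in this assay, within a range from 1000 nM to 12000 nM.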

Compound 4, half-maximal inhibitory concentration: > 10000 nM
Compound 4: a limit, no number (the forecaster's own chance of this, stated with the estimate: 5%); at least 2.8-fold (0.45 log units) between middle value and limit.
By their numbers in this assay, from the lowest: compound 3; then compounds 1 and 2 (each within the scatter of the next). At a limit, above all of these: compound 4.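

In this assay compound 4 gives only a limit, not a number: the limit of > 10000 nM in this assay, at which 1 of the 4 values shown sits. At this carbonyl carbon, replacing thiophen-2-yl with 2-amino-4-methylpyrimidin-5-yl gives a large loss, an at least 13-fold higher number from compound 3 to compound 4 (1.14 log units; beyond the scatter). The number also rises with an at least 2.1-fold higher number from compound 1 to compound 4 (0.32 log units; beyond the scatter), whereas an at least 1.5-fold higher number from compound 2 to compound 4 (0.18 log units; that floor lies within the scatter) leaves the order of that pair unsettled.

The compounds shown do not separate the roles of the amino group, the methyl group and the ring nitrogens in this loss. They also do not tell how a furan-2-yl on this carbonyl carbon would compare with thiophen-2-yl.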